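Naphthylidene thiazolidinedione amides: aryl variation at the amide nitrogen

The source may report more compounds than this note shows. Statements on the series, on what has been measured and on what is new or still open speak of the compounds shown alone.

Measured compounds:
compound 1, `Cc1ccc(NC(=O)COc2ccc3cc(/C=C4/SC(=O)NC4=O)ccc3c2)cc1`, 1700 nM
compound 2, `Cc1cccc2sc(NC(=O)COc3ccc4cc(/C=C5/SC(=O)NC5=O)ccc4c3)nc12`, 1200 nM
compound 3, `O=C(COc1ccc2cc(/C=C3/SC(=O)NC3=O)ccc2c1)Nc1ccc(Cl)c(Cl)c1`, 5500 nM

All three share one core and differ only in the group on the amide-type nitrogen. In an assay on isolated protein for inhibition of histone deacetylase 4 (Homo sapiens), with a stated time of 1 h (a higher number here means a weaker inhibitor, a lower number a stronger inhibitor), compound 1 gives 1700 nM, the second highest of the three numbers; its nearest neighbour is compound 2 with a 1.4-fold lower number from compound 1 to compound 2 (0.15 log units; within the scatter), while compound 3 lies furthest with a 3.2-fold higher number from compound 1 to compound 3 (0.51 log units; beyond the scatter). Compound 2 against compound 3 shows a 4.6-fold higher number from compound 2 to compound 3 (0.66 log units; beyond the scatter).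

Compound 4, `O=C(COc1ccc2cc(/C=C3/SC(=O)NC3=O)ccc2c1)Nc1c(F)cc(F)cc1Br`, has not yet been measured. It differs from compound 1 by 2-bromo-4,6-difluorophenyl in place of 4-methylphenyl on an amide-type nitrogen. For the measured compounds named here, the step that bears on it is the one to compound 3, where a 3,4-dichlorophenyl replaced the same 4-methylphenyl and gave a 3.2-fold higher number from compound 1 to compound 3 (0.51 log units; beyond the scatter); the step to compound 2 stayed within the scatter. A modest rise in the number is therefore expected for compound 4, estimated as a 2.4-fold higher number from compound 1 to compound 4 (0.37 log units; beyond the scatter) in this assay, giving an estimate of 4000 nM, within 1500 nM to 10000 nM.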

Compound 4, half-maximal inhibitory concentration: 1100 nM
Estimate against measurement, compound 4: 3.6-fold (0.56 log units) above; the whole stated range lies above it.
By their numbers in this assay, from the lowest: compounds 4, 2 and 1 (each within the scatter of the next); then compound 3.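

In this assay, a halogen-bearing phenyl group on the amide-type nitrogen does not by itself bring a rise in the number: 2-bromo-4,6-difluorophenyl stays level with 4-methylphenyl (a 1.5-fold lower number from compound 1 to compound 4 (0.19 log units; within the scatter)) and with 4-methyl-1,3-benzothiazol-2-yl (a 1.1-fold lower number from compound 2 to compound 4 (0.04 log units; within the scatter)). The 3,4-dichlorophenyl group alone stands apart among the four, and exchanging it for 2-bromo-4,6-difluorophenyl is a step beyond the scatter (a 5.0-fold lower number from compound 3 to compound 4 (0.70 log units; beyond the scatter)), so the outcome at this position depends on more than the presence of halogen. Nothing available here accounts for the gap between the two halogen-bearing phenyl groups.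

Still open, on these data alone, is whether the bromine or the fluorines of compound 4 matter singly, as a 2-bromophenyl or a 2,4-difluorophenyl group would show. Also open, as far as these compounds go, is how this position responds to a group without an aromatic ring, such as an alkyl chain bearing an amine or a carboxylic acid.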